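Phenyl for Pentan-3-yl on an Acetoxymethyl Enone Chain

This account rests on a few compounds, and the source may have more. Where it says the series, first, only, none or still open, it means among the compounds named here.

Among the compounds with values here, compound 3 `CCC(/C=C(\COC(C)=O)C(=O)c1ccccc1)CC` gives 50000 nM in a functional assay on HeLa cells (Homo sapiens) for inhibition, read by sulforhodamine B assay, with a stated time of 48 h (a lower number here means a stronger inhibitor of growth, a higher number a weaker inhibitor of growth), the highest of the three numbers measured so far; compound 1 `O=C(/C(=C/c1ccccc1)CCl)c1ccccc1` gives 23000 nM and compound 2 `CC(=O)OC/C(=C\C1CCCCC1)C(=O)c1ccccc1` gives 21000 nM. Compound 4 `CC(=O)OC/C(=C\c1ccccc1)C(=O)c1ccccc1` differs from compound 3 by phenyl in place of pentan-3-yl on a double-bonded chain carbon bound to a double-bonded chain carbon. Within the data shown here, only one measured step touches this position: a 2.4-fold higher number from compound 2 to compound 3 (0.38 log units; beyond the scatter), a modest rise when cyclohexyl gave way to pentan-3-yl. Compound 4 returns a ring there, and compound 1, which also carries phenyl at that place, sits close to compound 2. A modest fall back toward those two numbers is therefore expected, a 2.3-fold lower number from compound 3 to compound 4 (0.36 log units; beyond the scatter). Compound 4 is expected to give about 22000 nM, within the range 10000 nM to 50000 nM.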

Compound 4, concentration for 50% growth inhibition: 20000 nM
Beside the measured number, compound 4's estimate is 1.1-fold (0.04 log units) above it, within the range that was stated.
By their numbers in this assay, from the lowest: compounds 4, 2 and 1 (each within the scatter of the next); then compound 3.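

Phenyl in place of pentan-3-yl brings a 2.5-fold lower number from compound 3 to compound 4 (0.40 log units; beyond the scatter). Phenyl and cyclohexyl at this place cannot be told apart, with only a 1.1-fold lower number from compound 2 to compound 4 (0.02 log units; within the scatter), so among these three groups pentan-3-yl, the one without a ring, gives the highest number. Acetoxy and chloro on the saturated chain carbon also cannot be told apart, with only a 1.2-fold lower number from compound 1 to compound 4 (0.06 log units; within the scatter).

No evidence here explains why the ringless group differs. Going by these compounds, it remains open whether an amine or a carboxylic acid on the phenyl ring would move the number beyond the scatter.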